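The source may report more compounds than this note shows. Statements on the series, on what has been measured and on what is new or still open speak of the compounds shown alone.

Measured compounds:
- Compound 1 `C=C1C[C@]23C[C@@]1(O)CC[C@H]2c1ccc(O)c(C)c1[C@@H]3Cn1cc(-c2ccccn2)nn1`. In a functional assay on A549 cells (Homo sapiens) for cytotoxicity, read by MTT assay, with a stated time of 4 days (a lower number here means a stronger inhibitor, a higher number a weaker inhibitor), compound 1 gives > 20000 nM, which is a limit of the assay and not a number.
- Compound 2 `C=C1C[C@]23C[C@@]1(O)CC[C@H]2c1ccc(OS(=O)(=O)c2ccc(C)cc2)c(C)c1[C@@H]3Cn1cc(-c2ccc(C)cc2)nn1`. In this assay compound 2 gives > 20000 nM, again a limit of the assay.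
- Compound 3 `C=C1C[C@]23C[C@@]1(O)CC[C@H]2c1ccc(O)c(C)c1[C@@H]3Cn1cc(-c2ccc(C)cc2)nn1`. In this assay compound 3 gives > 20000 nM, also a limit of the assay.

Compound 2 therefore stands only at a limit in this assay, as do the other two measured members of the series: the limit of > 20000 nM in this assay, at which 3 of the 3 values shown sit.

Compound 4 `C=C1C[C@]23C[C@@]1(O)CC[C@H]2c1ccc(OS(=O)(=O)c2ccc(C)cc2)c(C)c1[C@@H]3Cn1cc(-c2ccccn2)nn1` has not yet been measured. It differs from compound 2 in one place: pyridin-2-yl in place of 4-methylphenyl on an aromatic carbon.

Among the measured compounds shown here, two measured steps bear on this change. For the measured compounds named here, the first is the same exchange in the other direction, made on the free phenol: a step that the two limits leave unreadable from compound 1 to compound 3. The second is the change of the phenol to its sulfonate ester with the 4-methylphenyl triazole held constant: a step that the two limits leave unreadable from compound 2 to compound 3. Neither step can be read, since both ends of each sit at the limit, so no direction or size beyond the scatter can be taken from them for this assay.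

With every measured value at the limit, the expectation for compound 4 is that it also sits at the limit. The step is expected to be a step that the limit leaves unreadable from compound 2 to compound 4. For compound 4 the estimate is 40000 nM, with a range from 15000 nM to 120000 nM.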

Compound 4, half-maximal inhibitory concentration: > 20000 nM
Compound 4: a limit, no number (the forecaster's own chance of this, stated with the estimate: 85%); the middle value does not contradict the limit.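

Neither the step from compound 2 to compound 4 nor the step from compound 1 to compound 4 can be read in this assay, as both ends of each are limits and not numbers: the limit of > 20000 nM in this assay, at which 4 of the 4 values shown sit.

The compounds shown leave open whether pyridin-2-yl, 4-methylphenyl or (4-methylphenyl)sulfonyl affects cytotoxicity, and how these compounds rank.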